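The source may report more compounds than this note shows. Statements on the series, on what has been measured and on what is new or still open speak of the compounds shown alone.

In a functional assay on MCF7 cells (Homo sapiens), read by MTT assay, with a stated time of 48 h (on this read-out lower numbers stand for stronger inhibition and higher numbers for weaker inhibition), three amides on the shared core have been measured. Compound 1 `CCOC(=O)CN(C)C(=O)c1ccc(C(CC)(CC)c2ccc(OCC(O)C(C)(C)C)c(C)c2)n1CC` gives 9200 nM. Compound 2 `C#CCNC(=O)c1ccc(C(CC)(CC)c2ccc(OCC(O)C(C)(C)C)c(C)c2)n1CC` gives > 50000 nM, which is a limit of the assay and not a number. Compound 3 `CCn1c(C(=O)NCCN)ccc1C(CC)(CC)c1ccc(OCC(O)C(C)(C)C)c(C)c1` gives 5.9 nM, the lowest of the numbers shown.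

The change to compound 4 `C=CCN(C)C(=O)c1ccc(C(CC)(CC)c2ccc(OCC(O)C(C)(C)C)c(C)c2)n1CC` is allyl(methyl)amino in place of (2-aminoethyl)amino on a carbonyl carbon. Among the compounds with values here, two measured steps bear most directly on this, a 1600-fold lower number from compound 1 to compound 3 (3.19 log units; beyond the scatter) and an at least 8400-fold lower number from compound 2 to compound 3 (3.92 log units; beyond the scatter). Both are large, lie beyond the scatter and end on the (2-aminoethyl)amino group, which compound 4 lacks. Between the two amides without that group, an at least 5.4-fold higher number from compound 1 to compound 2 (0.73 log units; beyond the scatter) is at least modest.

Compound 4 is therefore expected to sit nearer compound 1, at 9200 nM, than compound 3. A large move to a higher number is expected, estimated as a 2500-fold higher number from compound 3 to compound 4 (3.41 log units; beyond the scatter). For compound 4, the estimated value is 15000 nM, with an expected range of 4000 nM to 50000 nM.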

Compound 4, half-maximal inhibitory concentration: > 50000 nM
Compound 4: no number, only a limit; the forecaster's own chance of this, stated with the estimate: 35%; middle value at least 3.3-fold (0.52 log units) away from the limit.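

In this assay, compound 4 gives a limit of the assay and not a number, and the step between compound 2 and compound 4 cannot be read, as both stand at that limit: the limit of > 50000 nM in this assay, at which 2 of the 4 values shown sit. Allyl(methyl)amino on the carbonyl carbon gives an at least 8400-fold higher number from compound 3 to compound 4 (3.92 log units; beyond the scatter), which makes it a third amide without (2-aminoethyl)amino that lies far from compound 3, and none of the four compounds goes against this pattern. Vinyl in place of ethoxycarbonyl on the chain gives an at least 5.4-fold higher number from compound 1 to compound 4 (0.73 log units; beyond the scatter), leaving compound 1 as the only one of these three amides with a number.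

Whether the amine or the two-carbon chain of (2-aminoethyl)amino accounts for the low number of compound 3 remains open. A (2-hydroxyethyl)amino group or a (3-aminopropyl)amino group on the same carbonyl carbon would separate the two.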